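Compound 3 to compound 4: a new carbonyl substituent

A few compounds are considered here, and "the series" means these few. Any claim that something is new, unique, unknown or untested is made for them only; others in the source may bear on it.

In a functional assay on A549 cells (Homo sapiens) for antiproliferative activity, read by MTT assay, with a stated time of 72 h (on this read-out lower numbers stand for stronger inhibition and higher numbers for weaker inhibition), compound 3 `O=C(Nc1ccc(Nc2nccc(NC3CCCC3)n2)cc1)Nc1cccc(C(F)(F)F)c1` gives 4900 nM and compound 1 `O=C(Nc1ccc(Nc2nccc(NC3CCCC3)n2)cc1)Nc1ccc(Cl)c(C(F)(F)F)c1` gives 5880 nM, level within the scatter. Compound 2 `O=C(Nc1ccc(Nc2nccc(Nc3ccccc3)n2)cc1)Nc1ccc(Cl)c(C(F)(F)F)c1` gives > 50000 nM, which is a limit of the assay. Compound 4 `O=C(CC1CCCCC1)Nc1ccc(Nc2nccc(NC3CCCC3)n2)cc1` carries cyclohexylmethyl in place of (3-(trifluoromethyl)phenyl)amino on a carbonyl carbon. Within the data shown here, no measured step changes this whole group. The nearest, a 1.2-fold lower number from compound 1 to compound 3 (0.08 log units; within the scatter), only swaps chloro for hydrogen on its aromatic ring. The other, an at least 8.5-fold higher number from compound 1 to compound 2 (0.92 log units; beyond the scatter), concerns the cyclopentyl group, which compound 4 keeps. With so little support, a modest move to a higher number in this assay is expected, estimated as a 2.2-fold higher number from compound 3 to compound 4 (0.35 log units; beyond the scatter). For compound 4 the estimate is 11000 nM, with an expected range of 3000 nM to 40000 nM.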

Compound 4, half-maximal inhibitory concentration: 3940 nM
Compound 4: the middle estimate sits 2.8-fold (0.45 log units) above what was measured; the range from low to high includes it.
By their numbers in this assay, from the lowest: compounds 4, 3 and 1 (each within the scatter of the next). At a limit, above all of these: compound 2.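

In this assay, exchanging the whole group on the carbonyl carbon gives a 1.2-fold lower number from compound 3 to compound 4 (0.09 log units; within the scatter), a far larger structural change than the chloro step on the aromatic ring. The (3-(trifluoromethyl)phenyl)amino group, with its aromatic ring and hydrogen-bond donor, can therefore give way to cyclohexylmethyl with no shift beyond the scatter. Nothing shown here gives a cause for this step.

Still open, on these data alone, is how a longer chain ending in an amine or a carboxylic acid would read at this carbonyl carbon. As far as these compounds go, whether cyclohexylmethyl keeps this level with phenyl in place of cyclopentyl also remains open.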